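This account rests on a few compounds, and the source may have more. Where it says the series, first, only, none or still open, it means among the compounds named here.

Measured compounds:
- compound 1, `CCCC(N)C(=O)NCc1ccccc1`: 39 mg/kg
- compound 2, `CCC[C@@H](N)C(=O)NCc1ccccc1`: 21 mg/kg
- compound 3, `C=CCOCC(N)C(=O)NCc1ccccc1`: 45 mg/kg

All values come from a functional assay on the whole organism (strain NMRI) with Mus musculus as the target, in the maximal electroshock model, with a stated time of 30 min; on this read-out lower numbers stand for an effect already at smaller amounts and higher numbers for an effect only at larger amounts of compound. Compound 3 carries the highest number of the three; its nearest neighbour is compound 1, within the scatter, and its furthest is compound 2, beyond the scatter. Between compound 1 and compound 2, a 1.9-fold lower number from compound 1 to compound 2 (0.27 log units; within the scatter), the two differing only in that (the fact that one of compounds 1 and 2 is drawn with a defined configuration and the other without, at the place where they differ). Between compound 1 and compound 3, a 1.2-fold higher number from compound 1 to compound 3 (0.06 log units; within the scatter), so allyloxy in place of ethyl left this assay essentially unchanged.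

Compound 4, `NCC(N)C(=O)NCc1ccccc1`, is not yet measured in this assay. It differs from compound 3 by amino in place of allyloxy on a saturated chain carbon, two bonds along the chain from an amine nitrogen and a carbonyl carbon. For the measured compounds named here, no measured step covers an amine entering at this place; the only side-chain exchange on record, from compound 1 to compound 3, stayed within the scatter, and the stereo step likewise. The expectation is therefore a step of modest size at most, a 1.8-fold higher number from compound 3 to compound 4 (0.25 log units; within the scatter), with a lean towards a higher number but no firm ground for it. Compound 4 is estimated at 80 mg/kg in this assay, within the range 30 mg/kg to 250 mg/kg.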

Compound 4, dose for half-maximal effect: > 68 mg/kg
Compound 4 gave a limit, no number; the forecaster's own chance of this, stated with the estimate: 30%; the middle value is on the limit's open side.
By their numbers in this assay, from the lowest: compounds 2, 1 and 3 (each within the scatter of the next, the first and the last beyond it). At a limit, above all of these: compound 4.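

In the maximal electroshock read-out of this assay, amino at this place, on a saturated chain carbon, gives no number: compound 4 gives > 68 mg/kg as a limit. The steps read as floors, with an at least 1.5-fold higher number from compound 3 to compound 4 (0.17 log units; that floor lies within the scatter) and an at least 1.7-fold higher number from compound 1 to compound 4 (0.24 log units; that floor lies within the scatter) both not shown to leave the scatter, though either may be larger. Only an at least 3.2-fold higher number from compound 2 to compound 4 (0.51 log units; beyond the scatter) is beyond the scatter, and it starts from a compound with a drawn configuration, so this comparison also carries the difference seen earlier: the fact that one of compounds 1 and 2 is drawn with a defined configuration and the other without, at the place where they differ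

From the compounds shown here alone, how far compound 4 lies past its limit remains open, so the full size of the change from allyloxy to amino cannot be given. Also open, going by these compounds, is whether a longer chain ending in an amine, or a carboxylic acid, at this place would give a number in this assay or another limit.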